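A few compounds are considered here, and "the series" means these few. Any claim that something is new, unique, unknown or untested is made for them only; others in the source may bear on it.

Measured so far:
- compound 1, `O=C(CCN1CCN(c2ccnc3cc(Cl)ccc23)CC1)N/N=C/c1ccccc1Cl`, 10800 nM
- compound 2, `CC(C)c1ccc(/C=N/NC(=O)CCN2CCN(c3ccnc4cc(Cl)ccc34)CC2)cc1`, 7900 nM

In an ADME assay on cells (Splenocyte, Mus musculus, strain BALB/c) for cytotoxicity, read by thymidine incorporation, with a stated time of 24 h (a higher number here means a weaker inhibitor, a lower number a stronger inhibitor), compound 2 gives the lowest of the two numbers; its nearest neighbour is compound 1, and the step of a 1.4-fold lower number from compound 1 to compound 2 (0.14 log units; within the scatter) lies within the scatter, so the two cannot be told apart. Compound 3, `COc1cc(/C=N/NC(=O)CCN2CCN(c3ccnc4cc(Cl)ccc34)CC2)ccc1OC(C)C`, has not yet been measured. It differs from compound 2 by 4-isopropoxy-3-methoxyphenyl in place of 4-isopropylphenyl on a carbon with a double bond to nitrogen. For the measured compounds named here, the only measured step, from compound 1 to compound 2, also swaps the group on this same carbon and produced no change beyond the scatter. Going by the values given here, no step tests an alkoxy or methoxy group at this place, so nothing in the data argues for a marked move in either direction. Compound 3 is therefore expected to sit near compound 2, with an estimated step of a 1.0-fold higher number from compound 2 to compound 3 (0.01 log units; within the scatter) in this assay. The expected value for compound 3 is 8000 nM, within a range of 3500 nM to 18000 nM.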

Compound 3, half-maximal inhibitory concentration in the Splenocyte assay: 8800 nM
Compound 3: the middle estimate sits 1.1-fold (0.04 log units) below what was measured; the measured number falls inside the stated range.
By their numbers in the Splenocyte assay, from the lowest: compounds 2, 3 and 1 (each within the scatter of the next).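

In the Splenocyte assay the change of group on this carbon shows no effect that can be read: the steps are a 1.1-fold higher number from compound 2 to compound 3 (0.05 log units; within the scatter) and a 1.2-fold lower number from compound 1 to compound 3 (0.09 log units; within the scatter), so the three aryl groups tried here cannot be told apart. The same change from 4-isopropylphenyl to 4-isopropoxy-3-methoxyphenyl does separate the compounds in a physicochemical assay for inhibition, read by spectrophotometry, with a stated time of 24 h, tested at 2.5 mM (a lower number here means less inhibition, a higher number more inhibition at the concentration tested (going by the name of the read-out)), where compound 2 gives 94% and compound 3 gives 15.7%, a gap far beyond the scatter. This position can therefore matter strongly for one read-out while making no visible difference to the other.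

The methoxy and isopropoxy groups enter together, so which of them accounts for the gap stays open. Also open, going by these compounds, is what an amine or a carboxylic acid on the phenyl ring would do in these two tests.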